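Swapping the aryl group on a shared tetrabromo core

The source may report more compounds than this note shows. Statements on the series, on what has been measured and on what is new or still open speak of the compounds shown alone.

Compound 1 `OC(CCn1nc2c(Br)c(Br)c(Br)c(Br)c2n1)c1ccc(F)cc1` gives 0% in a functional assay on MCF7 cells (Homo sapiens) for antiproliferative activity, read by MTT assay, with a stated time of 48 h, tested at 100 uM; a lower number here means a stronger effect, a higher number a weaker effect of the compound at the concentration tested. Compound 2 `COc1cccc(C(O)CCn2nc3c(Br)c(Br)c(Br)c(Br)c3n2)c1` gives 6% in this assay. Compound 3 `CC(O)CCn1nc2c(Br)c(Br)c(Br)c(Br)c2n1` gives 0% in this assay.

Compound 2 stands at one end of these three numbers, but its neighbours sit close: the step of a number 6 percentage points higher from compound 1 to compound 2 (within the scatter) and the step of a number 6 percentage points lower from compound 2 to compound 3 (within the scatter) both lie within the scatter, so the three compounds cannot be told apart. Compound 4 `OC(CCn1nc2c(Br)c(Br)c(Br)c(Br)c2n1)c1ccc(Cl)cc1` is the next to be measured. It differs from compound 2 by 4-chlorophenyl in place of 3-methoxyphenyl on a saturated chain carbon bound to an oxygen on a saturated carbon and a saturated chain carbon. Every exchange seen so far at this place, whether aryl for aryl or methyl for aryl, left the read-out essentially flat, so no step beyond the scatter is expected for a number 4 percentage points lower from compound 2 to compound 4 (within the scatter). Compound 4 is therefore estimated at 2%, between 0% and 12%.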

Compound 4, a percentage reported as activity, at one concentration (the size of the read-out at that concentration, not a potency): 0%
For compound 4 the middle estimate is 2 percentage points above the measured one, within the range that was stated.
By their numbers in this assay, from the lowest: compounds 1, 3, 4 and 2 (each within the scatter of the next).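

Chloro in place of fluoro on an aromatic carbon is the first change made on the ring itself, and it gives no change at the digits printed from compound 1 to compound 4 (within the scatter) in this assay at this position. The larger exchanges agree: 4-chlorophenyl in place of 3-methoxyphenyl gives a number 6 percentage points lower from compound 2 to compound 4 (within the scatter) and 4-chlorophenyl in place of methyl gives no change at the digits printed from compound 3 to compound 4 (within the scatter) so neither step separates the compounds. Going by these compounds, whether an amine, a carboxylic acid or a longer chain at this place would move the read-out stays open. Nothing available explains why the read-out stays flat.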